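Amide series on a shared core: removing the trifluoromethyl

A few compounds are considered here, and "the series" means these few. Any claim that something is new, unique, unknown or untested is made for them only; others in the source may bear on it.

Compound 1 `O=C(Nc1ccc(Cl)c(-c2nnc3c(Cl)cccn23)c1)c1ccc(C(F)(F)F)cc1Cl` was run in a functional assay on MDA-MB-231 cells (Homo sapiens) for antiproliferative activity, read by MTT assay, with stated times of 72 h and 4 h; on this read-out higher numbers stand for weaker inhibition and lower numbers for stronger inhibition. In this assay compound 1 gives > 100000 nM, which is a limit of the assay and not a number. Compound 2 `O=C(Nc1ccc(Cl)c(-c2nnc3c(Cl)cccn23)c1)c1ccc(Cl)cc1` gives in this assay > 100000 nM, again a limit. Compound 3 `O=C(Nc1ccc(Cl)c(-c2nnc3c(Cl)cccn23)c1)c1c(F)cccc1Cl` gives in this assay > 100000 nM, also a limit. Within the data shown here, the one single-site step, a step that the two limits leave unreadable from compound 2 to compound 3, is therefore unreadable, and the limit of > 100000 nM in this assay, at which 3 of the 3 values shown sit, describes every value shown so far. Compound 4 `O=C(Nc1ccc(Cl)c(-c2nnc3c(Cl)cccn23)c1)c1ccccc1Cl` differs from compound 1 by hydrogen in place of trifluoromethyl on an aromatic carbon. Among the measured compounds shown here, no measured step bears on this change, so no shift beyond the scatter is expected. Compound 4 is estimated at 100000 nM, with a range from 30000 nM to 300000 nM, most probably reported once more as a limit. The step of a number no higher from compound 1 to compound 4 (the limit leaves the size open) is thus expected to be flat.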

Compound 4, half-maximal inhibitory concentration: 59900 nM
Compound 4: the middle estimate sits 1.7-fold (0.22 log units) above what was measured; the range from low to high includes it.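

In this assay, among these compounds, hydrogen in place of trifluoromethyl gives an at least 1.6-fold lower number from compound 1 to compound 4 (0.22 log units; that floor lies within the scatter), so this position yields the first actual number, though the floor does not separate the change from the scatter. Hydrogen in place of fluoro gives an at least 1.6-fold lower number from compound 3 to compound 4 (0.22 log units; that floor lies within the scatter), and 2-chlorophenyl in place of 4-chlorophenyl gives an at least 1.6-fold lower number from compound 2 to compound 4 (0.22 log units; that floor lies within the scatter). Only compound 4 carries a number, and the others remain limits: the limit of > 100000 nM in this assay, at which 3 of the 4 values shown sit.

On these data alone, the true sizes of all three steps stay open. Also open, as far as these compounds go, is whether an amine or a carboxylic acid on this aromatic carbon would move the number beyond the scatter.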